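The compounds below may be only part of what the source reports. "The series", "measured", "known", "first", "only" and "open" are said of these compounds alone.

Measured compounds:
- compound 1, `Cc1cccc(N2CCN(C(=O)CN3C(=O)CC(C)(c4ccccc4)C3=O)CC2)c1`, in a functional assay on the whole organism (strain CD-1) with Mus musculus as the target, with a stated time of 0.5 h; a lower number here means that less compound is needed, a higher number that more compound is needed for the effect: "not active" (no number reported)
- compound 2, `CC1(c2ccccc2)CC(=O)N(CC(=O)N2CCN(c3cccc(Cl)c3)CC2)C1=O`: "not active" (no number reported)
- compound 3, `CC1(c2ccccc2)CC(=O)N(CC(=O)N2CCC(Cc3ccccc3)CC2)C1=O`: 100 mg/kg

Compound 1 stands without a number in this assay; it is reported as "not active" (no number reported), and compound 2 shares that outcome with no number of its own. Compound 3 is the only one of the three for which a minimum effective dose was recorded, and compound 3 gives 100 mg/kg in this assay. Among the compounds with values here, with two of three entries lacking a number, no step between measured compounds can be drawn, and the series gives no ordering beyond the fact that compound 3 alone reached a reported dose.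

Compound 4, `CC1(c2ccccc2)CC(=O)N(CC(=O)N2CCN(c3ccccc3)CC2)C1=O`, is not yet measured. It differs from compound 1 in one place: hydrogen in place of methyl on an aromatic carbon. Read one bond further out, the change is 3-methylphenyl to phenyl on the shared core of compound 1.

Since no step is shown for any pair, the size of the change in this assay for compound 4 cannot be anchored; the account expects at most a move within the usual scatter of compound 1, and quite possibly again no number at all. For compound 4 the estimated minimum effective dose is 150 mg/kg, with an expected range from 50 mg/kg to 400 mg/kg.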

Compound 4, minimum effective dose: 100 mg/kg
The estimate for compound 4 lay 1.5-fold (0.18 log units) above the measured number; the measured number falls inside the stated range.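

In this assay compound 4 gives 100 mg/kg while compound 1 is recorded as "not active" (no number reported) and so no step can be read between the two. Nothing measured here bears on a cause for this result. The compounds shown leave open how much 3-methylphenyl and phenyl differ in this read-out on the shared core.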